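A Larger Ring Group on Compound 3

A few compounds are considered here, and "the series" means these few. Any claim that something is new, unique, unknown or untested is made for them only; others in the source may bear on it.

Three compounds share one core, and they differ in the aromatic group it carries. Among the compounds with values here, in a physicochemical assay for lipophilicity, read by LC-MS, in phosphate buffer, measured as octanol-water partition, at pH 7.4, tested at 66.7 uM (a lower number here means a more polar compound, a higher number a more lipophilic compound), compound 3 `CN1CCN(c2ccc(Nc3nccc(-c4ccnc(Cl)c4)n3)cc2C(F)(F)F)CC1` gives 4.3, the only true number among them. Compound 1 `CN1CCN(c2ccc(Nc3nccc(-c4cccc(Cl)c4)n3)cc2C(F)(F)F)CC1` reads > 6, which is a limit of the assay and not a number. Compound 2 `CN1CCN(c2ccc(Nc3nccc(-c4ccc5ccccc5c4)n3)cc2C(F)(F)F)CC1` reads > 5.7, which is also a limit.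

Compound 4 `CN1CCN(c2ccc(Nc3nccc(-c4cnn5ncccc45)n3)cc2C(F)(F)F)CC1` keeps the core of compound 3 but exchanges its 2-chloropyridin-4-yl group on an aromatic carbon: a group of 9 heavy atoms (6 carbon, 3 nitrogen; one five-membered aromatic ring with 2 hetero atoms, one six-membered aromatic ring with 2 hetero atoms) in place of a group of 7 heavy atoms (5 carbon, 1 nitrogen, 1 chlorine; one six-membered aromatic ring with 1 hetero atom), on an aromatic carbon. The two groups differ in hetero atoms and hydrogen-bond acceptors, and the entering group has more of both.

Within the data shown here, two measured steps bear on this, as both end on the 2-chloropyridin-4-yl group. One is a number at least 1.70 log units lower from compound 1 to compound 3 (beyond the scatter), the other a number at least 1.40 log units lower from compound 2 to compound 3 (beyond the scatter). Both are large falls, and both lead to the group with a ring hetero atom. The step that the two limits leave unreadable from compound 1 to compound 2 adds nothing. Among the measured compounds shown here, no measured step starts from compound 3, so the direction is an inference and the size is uncertain.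

A fall is expected in this assay, estimated as smaller than those two: a number 0.60 log units lower from compound 3 to compound 4 (beyond the scatter). Compound 4 is expected at 3.7, with an estimated range of 3.1 to 4.3.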

Compound 4, distribution coefficient: 3.71
Beside the measured number, compound 4's estimate is 0.01 log units below it, within the range that was stated.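

In this assay, this is the first step shown that starts from compound 3: a number 0.59 log units lower from compound 3 to compound 4 (beyond the scatter). It shows that the 2-chloropyridin-4-yl group is not the lowest reading this position can give, since a larger, chlorine-free group with two aromatic rings and more hydrogen-bond acceptors reads lower still, and compound 4 now has the lowest value of the four compounds. Measured against the carbon-only aromatic groups, the same exchange gives a number at least 1.99 log units lower from compound 2 to compound 4 (beyond the scatter) and a number at least 2.29 log units lower from compound 1 to compound 4 (beyond the scatter), and each size is only a minimum because the starting reading is a limit and not a number: the limit of > 5.7 in this assay, at which 1 of the 4 values shown sits; the limit of > 6 in this assay, at which 1 of the 4 values shown sits.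

The entering group differs from the 2-chloropyridin-4-yl group in its chlorine, its ring count and its ring nitrogens all at once, so the compounds shown cannot tell which of these differences accounts for the fall. On these data alone, a plain pyridin-4-yl group without the chlorine, or a single five-membered ring such as pyrazol-4-yl on the same aromatic carbon, would begin to separate them, and how either would read remains open.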